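The compounds below may be only part of what the source reports. "The series", "measured", "known", "first", "only" and "open" are said of these compounds alone.

Compound 1, with the structure `ClCc1ccccc1Cn1cnc2c(Cl)ncnc21`, carries a chloromethyl group and a chlorinated fused core joined through a benzylic linker. In a functional assay on HOP-92 cells (Homo sapiens) for cytotoxicity, read by sulforhodamine B assay, with a stated time of 48 h (on this read-out higher numbers stand for weaker inhibition of growth and lower numbers for stronger inhibition of growth), compound 1 gives 4260 nM. Compound 2, with the structure `ClCc1cccc(Cn2cnc3ncnc(Cl)c32)c1`, moves the chloromethyl group to another position of the benzene ring, yet in this assay compound 2 gives "not determined" (no result reported), so no number stands for it and its position relative to compound 1 cannot be read from the data. Compound 3, with the structure `ClCc1cccc(Cn2cnc3nc(Cl)nc(Cl)c32)c1`, differs from compound 2 in one place: chloro in place of hydrogen on an aromatic carbon. Without a measured step for such a change, only a modest shift is anticipated, probably toward stronger inhibition of growth but not clearly beyond the usual scatter of this assay. On that basis compound 3 is expected to reach about 3000 nM, within a range from 800 nM to 12000 nM.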

Compound 3, concentration for total growth inhibition: 2750 nM
Compound 3: the middle estimate sits 1.1-fold (0.04 log units) above what was measured; measured number inside the range.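

In this assay, among these compounds, compound 2 carries no number, so no step to compound 3 can be read. The compounds shown leave open how the added chloro group on the shared core affects growth inhibition. Nothing given here offers an explanation for the value of compound 3.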